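The source may report more compounds than this note shows. Statements on the series, on what has been measured and on what is new or still open speak of the compounds shown alone.

Compound 1 `CCOC(=O)CCCCCCn1c(CC)nc(-c2ccccc2)c1-c1ccccc1` — in an assay on H4 cells for inhibition of Fatty-acid amide hydrolase 1 (Homo sapiens) (on this read-out higher numbers stand for weaker inhibition and lower numbers for stronger inhibition), compound 1 gives 11 nM.
Compound 2 `CCOC(=O)CC(CCCCCn1c(C)nc(-c2ccccc2)c1-c1ccccc1)C(C)C` — in this assay compound 2 gives > 100000 nM, which is a limit of the assay and not a number.

Compound 2 therefore stands at the weak end of what has been measured: its result is only a limit, (the limit of > 100000 nM in this assay, at which 1 of the 2 values shown sits), so how weak it truly is cannot be read from the numbers. Compound 3 `Cc1nc(-c2ccccc2)c(-c2ccccc2)n1CCCCCCNC(=O)Nc1ccccc1` has not yet been measured. It differs from compound 2 in one place: ((phenylcarbamoyl)amino)methyl in place of 1-((ethoxycarbonyl)methyl)-2-methylpropyl on a saturated chain carbon, five bonds along the chain from an aromatic nitrogen. For the measured compounds named here, no step between two measured compounds runs this way, so nothing measured says directly what this change does. Since compound 2 sits at the limit, the step can only move toward stronger inhibition or stay beyond the reach of the assay. Compound 1 shows that a straight chain on this core can give strong inhibition, 11 nM, and compound 3 carries a straight chain as well.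

Compound 3 is expected to give about 50 nM, with a range from 5 nM to 1500 nM. The estimated step from compound 2 to compound 3 is an at least 2000-fold lower number from compound 2 to compound 3 (3.30 log units; beyond the scatter), a large move toward stronger inhibition, though with a limit as the starting point its true size stays uncertain.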

Compound 3, half-maximal inhibitory concentration: 10000 nM
Compound 3: the middle estimate sits 200-fold (2.30 log units) below what was measured, outside the stated range (above it).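

In this assay compound 2 gives > 100000 nM, which is a limit of the assay and not a number. Putting ((phenylcarbamoyl)amino)methyl in place of 1-((ethoxycarbonyl)methyl)-2-methylpropyl on a saturated chain carbon, five bonds along the chain from an aromatic nitrogen, gives an at least 10-fold lower number from compound 2 to compound 3 (1.00 log units; beyond the scatter), so a change at this one place is enough to bring the read-out from the limit to a real number. The size of that step can only be given as a minimum, because its starting point is not a number: the limit of > 100000 nM in this assay, at which 1 of the 3 values shown sits.

The change swaps several features at once: the ethoxycarbonyl group and the branching leave, while the phenylcarbamoyl group and its two hydrogen-bond donors enter, so the compounds shown cannot tell which of these accounts for the step. Also open, going by these compounds, is how a simpler group at the same place would read, such as a plain amine, a carboxylic acid or an unbranched chain ending in ethoxycarbonyl on the core of compound 2, any of which would separate these features.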